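Swapping Chloro for Trifluoromethyl on the Outer Ring

A few compounds are considered here, and "the series" means these few. Any claim that something is new, unique, unknown or untested is made for them only; others in the source may bear on it.

Compound 1 `CCc1ccc(-c2c(NS(=O)(=O)c3ccc(C(C)(C)C)cc3)ncnc2OCCOc2ncc(SC)cn2)cc1`, compound 2 `CSc1cnc(OCCOc2ncnc(NS(=O)(=O)c3ccc(C(C)(C)C)cc3)c2-c2ccc(C(C)C)cc2)nc1` and compound 3 `CSc1cnc(OCCOc2ncnc(NS(=O)(=O)c3ccc(C(C)(C)C)cc3)c2-c2ccc(Cl)cc2)nc1` share one core and differ only in the group on the outer aromatic ring. In an assay on cells (Endothelial cell) for binding affinity to Endothelin-1 receptor (Sus scrofa) (on this read-out lower numbers stand for stronger inhibition and higher numbers for weaker inhibition), compound 1 gives 0.013 nM. Compound 2 gives 1.2 nM in this assay, and the change a 92-fold higher number from compound 1 to compound 2 (1.97 log units; beyond the scatter) shows that adding a methyl there raised the number sharply. For compound 3 this assay reports only a limit, < 0.001 nM, not a number. Compound 3 thus stands at the bottom of the values seen, sitting at the limit of < 0.001 nM in this assay, at which 1 of the 3 values shown sits. The steps of an at least 13-fold lower number from compound 1 to compound 3 (1.11 log units; beyond the scatter) and an at least 1200-fold lower number from compound 2 to compound 3 (3.07 log units; beyond the scatter) both point the same way: replacing the alkyl group with chloro lowered the number a great deal, though the true size of each step is hidden by the limit.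

Compound 4 `CSc1cnc(OCCOc2ncnc(NS(=O)(=O)c3ccc(C(C)(C)C)cc3)c2-c2ccc(C(F)(F)F)cc2)nc1` is compound 3 with trifluoromethyl in place of chloro on an aromatic carbon. Within the data shown here, no measured step involves trifluoromethyl, so the expectation rests on the pattern that chloro gave the lowest number while ethyl and isopropyl gave higher ones. Moving away from chloro is therefore expected to raise the number, with a step of about an at least 10-fold higher number from compound 3 to compound 4 (1.00 log units; beyond the scatter). Compound 4 is estimated at 0.01 nM in this assay, within a range of 0.001 nM to 0.1 nM.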

Compound 4, half-maximal inhibitory concentration: 0.0017 nM
Estimate against measurement, compound 4: 5.9-fold (0.77 log units) above, within the range that was stated.
By their numbers in this assay, from the lowest: compound 4; then compound 1; then compound 2. At a limit, below all of these: compound 3.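

Among these compounds, until now, chloro was the only group at this place, on an aromatic carbon para to a large group, that gave a number lower than those of the ethyl and isopropyl compounds, but trifluoromethyl does so too, with a 7.6-fold lower number from compound 1 to compound 4 (0.88 log units; beyond the scatter) and a 710-fold lower number from compound 2 to compound 4 (2.85 log units; beyond the scatter). So chloro is not alone in this, and a group of four heavy atoms in place of one still leaves the number lower than with either alkyl group. Against chloro itself the step reads an at least 1.7-fold higher number from compound 3 to compound 4 (0.23 log units; that floor lies within the scatter), which is only a floor, and the true gap cannot be read because the value for compound 3 is a limit and not a number: the limit of < 0.001 nM in this assay, at which 1 of the 4 values shown sits.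

The compounds shown leave open how far the low numbers extend to other groups at this place, such as fluoro, a nitrile or an amine. They also leave open whether chloro and trifluoromethyl truly differ here, since that would take a real number for compound 3.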